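Swapping the Amide-Side Aryl Group in a Shared Core

This account rests on a few compounds, and the source may have more. Where it says the series, first, only, none or still open, it means among the compounds named here.

Among the measured compounds shown here, compound 2 `CCc1cccc(NC(=O)CSc2nc(Nc3ccccc3)c3ccccc3n2)c1` gives 11000 nM in a functional assay on PC-3 cells (Homo sapiens) for inhibition, read by MTT assay, with a stated time of 72 h (on this read-out lower numbers stand for stronger inhibition and higher numbers for weaker inhibition), the lower of the two numbers so far, though its gap to compound 1 is within the scatter. Compound 1 `O=C(CSc1nc(Nc2ccccc2)c2ccccc2n1)Nc1cccc(F)c1` gives 15600 nM; the step of a 1.4-fold lower number from compound 1 to compound 2 (0.15 log units; within the scatter) is within the scatter, so the two compounds cannot be told apart. Compound 3 `O=C(CSc1nc(Nc2ccccc2)c2ccccc2n1)Nc1ccc(Cl)c(Cl)c1` has not been measured. It differs from compound 2 by 3,4-dichlorophenyl in place of 3-ethylphenyl on an amide-type nitrogen. For the measured compounds named here, no measured step covers this exact change; the one step available, a 1.4-fold lower number from compound 1 to compound 2 (0.15 log units; within the scatter), alters a group on the same ring that compound 3 changes and hardly moves the number. Going by the values given here, with that as the sole guide, the step from compound 2 to compound 3 is expected to be small and could go either way, a 1.1-fold lower number from compound 2 to compound 3 (0.04 log units; within the scatter). Compound 3 is therefore estimated at 10000 nM, within a range from 4000 nM to 30000 nM.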

Compound 3, half-maximal inhibitory concentration: 12100 nM
The estimate for compound 3 lay 1.2-fold (0.08 log units) below the measured number, and the stated range covers the measured number.
By their numbers in this assay, from the lowest: compounds 2, 3 and 1 (each within the scatter of the next).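

On the amide-type nitrogen, 3,4-dichlorophenyl now joins 3-ethylphenyl and 3-fluorophenyl, and in this assay both new steps stay within the scatter: a 1.1-fold higher number from compound 2 to compound 3 (0.04 log units; within the scatter) and a 1.3-fold lower number from compound 1 to compound 3 (0.11 log units; within the scatter). Among the compounds shown here, the earlier pair compared only two rings carrying one group each, whereas this ring carries two chlorine atoms, and the three compounds still cannot be told apart. Nothing at hand offers an explanation for this flat result.

As far as these compounds go, all three groups on this nitrogen are substituted phenyl rings, so it remains open whether something of another kind there, such as a ring bearing a carboxylic acid or amine, or a longer alkyl chain, would shift the number beyond the scatter. From the compounds shown here alone, the effect of changes elsewhere on the shared core also remains open.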